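The source may hold more compounds than are shown below. What is called first, only, known or untested is meant among the compounds shown, and "the series" means these compounds.

In an assay on cells for positive allosteric modulation of Cystic fibrosis transmembrane conductance regulator variant F508del (Homo sapiens), with stated times of 10 min and 7 s, in the presence of a further agent that is not named here (on this read-out higher numbers stand for an effect only at larger amounts of compound and lower numbers for an effect already at smaller amounts), the measured compounds are:

Compound 1, `CC1(C)Cc2c(sc(NC(=O)c3cccnc3O)c2C(N)=O)C(C)(C)O1`, gives 190 nM.
Compound 2, `CC1(C)Cc2c(sc(NC(=O)Cc3ccn[nH]3)c2C(N)=O)C(C)(C)O1`, gives 136 nM.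
Compound 3, `CC1(C)Cc2c(sc(NC(=O)C3(CO)CC3)c2C(N)=O)C(C)(C)O1`, gives 15 nM.

Compound 3 has the lowest number of the three: a 9.1-fold lower number from compound 2 to compound 3 (0.96 log units; beyond the scatter) and a 13-fold lower number from compound 1 to compound 3 (1.10 log units; beyond the scatter), both beyond the scatter. Compound 4, `CC1(C)Cc2c(sc(NC(=O)c3[nH]ncc3Cl)c2C(N)=O)C(C)(C)O1`, brings this change: a group of 6 heavy atoms (3 carbon, 2 nitrogen, 1 chlorine; one five-membered aromatic ring with 2 hetero atoms) in place of a group of 5 heavy atoms (4 carbon, 1 oxygen; one three-membered non-aromatic ring of carbon only), on a carbonyl carbon. Both steps that reached compound 3 replaced a group containing an aromatic ring with the 1-(hydroxymethyl)cyclopropyl group and lowered the number strongly; compound 4 goes the other way, back to an aromatic ring directly on the carbonyl carbon, as in compound 1. A higher number is therefore expected in this assay, and for compound 4 the estimate is 100 nM, between 30 nM and 400 nM, a step of a 6.7-fold higher number from compound 3 to compound 4 (0.82 log units; beyond the scatter).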

Compound 4, half-maximal effective concentration: 2 nM
Compound 4: the middle estimate sits 50-fold (1.70 log units) above what was measured; the measured number lies below the stated range.
By their numbers in this assay, from the lowest: compound 4; then compound 3; then compounds 2 and 1 (each within the scatter of the next).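

An aromatic ring directly on the carbonyl carbon is no drawback at this position: the chlorine-bearing five-membered aromatic ring gives a lower number than 1-(hydroxymethyl)cyclopropyl (a 7.5-fold lower number from compound 3 to compound 4 (0.88 log units; beyond the scatter)). The large steps of a 95-fold lower number from compound 1 to compound 4 (1.98 log units; beyond the scatter) and a 68-fold lower number from compound 2 to compound 4 (1.83 log units; beyond the scatter) show that which ring is present matters, as the groups replaced in those steps also hold an aromatic ring. No measurement available here accounts for this gain. Going by these compounds, what the chlorine itself contributes stays open: the same ring carrying a hydrogen, a methyl group or a nitrile in its place would test this.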